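A few compounds are considered here, and "the series" means these few. Any claim that something is new, unique, unknown or untested is made for them only; others in the source may bear on it.

Compound 1 `CS(=O)(=O)Nc1ccc2c(c1)S(=O)(=O)N=C(C1=C(O)[C@@H]3[C@H]4CC[C@H](C4)[C@@H]3N(Cc3ccccc3)C1=O)N2` was tested in an in vitro ADME assay on microsomes from liver (Homo sapiens) for metabolic stability, tested at 1 uM; a higher number here means that the compound lasts longer, a lower number that the compound disappears faster. In this assay compound 1 gives > 1 h, which is a limit of the assay rather than a number. Compound 2 `CS(=O)(=O)Nc1ccc2c(c1)S(=O)(=O)N=C(C1=C(O)[C@@H]3[C@H]4CC[C@H](C4)[C@@H]3N(Cc3ccc(F)c(F)c3F)C1=O)N2` differs from compound 1 only by a 2,3,4-trifluorophenyl in place of phenyl on a saturated chain carbon bound to an amide-type nitrogen in a ring, and compound 2 gives > 1 h, again a limit. Between them stands a step that the two limits leave unreadable from compound 1 to compound 2. Compound 3 `CS(=O)(=O)Nc1ccc2c(c1)S(=O)(=O)N=C(C1=C(O)[C@@H]3[C@H]4CC[C@H](C4)[C@@H]3N(CC3CCCCC3)C1=O)N2` instead carries cyclohexyl in place of phenyl on a saturated chain carbon bound to an amide-type nitrogen in a ring. Because (the limit of > 1 h in this assay, at which 2 of the 2 values shown sit), the expected step that the limit leaves unreadable from compound 1 to compound 3 stays within the scatter. Compound 3 is therefore estimated at 1.5 h, with a range from 0.7 h to 4 h.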

Compound 3, half-life: 0.733 h
The estimate for compound 3 lay 2.0-fold (0.31 log units) above the measured number; low and high end bracket the measured number.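

Among the compounds shown here, compound 3 is the first compound at this position to give a real number rather than a limit in this assay, so the change can now be sized, if only from one side. Putting the non-aromatic cyclohexyl ring at this place gives an at least 1.3-fold lower number from compound 1 to compound 3 (0.13 log units; that floor lies within the scatter), and against the fluorinated ring it gives an at least 1.3-fold lower number from compound 2 to compound 3 (0.13 log units; that floor lies within the scatter). Only these floors can be stated, because the other two values are limits: the limit of > 1 h in this assay, at which 2 of the 3 values shown sit.

On these data alone, the real size of both steps stays open, and so does whether either exceeds the scatter. As far as these compounds go, how an amine or a longer chain at this place would behave also remains unknown.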